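A few compounds are considered here, and "the series" means these few. Any claim that something is new, unique, unknown or untested is made for them only; others in the source may bear on it.

Of the compounds shown here, three that share one core have been tested in a functional assay on HepG2 cells (Homo sapiens) for cytotoxicity, read by MTT assay, with a stated time of 72 h; on this read-out higher numbers stand for weaker inhibition and lower numbers for stronger inhibition. Compound 1, `N#Cc1ccc(CN2CCC(NC(=O)COc3ccc4c(=O)c(-c5ccccc5)coc4c3)CC2)cc1`, returns only a limit of the assay, > 20000 nM. In other words, compound 1 sits at the limit of > 20000 nM in this assay, at which 1 of the 3 values shown sits. Compound 2, `COc1ccc(CN2CCC(NC(=O)COc3ccc(-c4cc(=O)c5ccccc5o4)cc3)CC2)cc1`, gives 6800 nM in this assay. Compound 3, `N#Cc1ccc(CN2CCC(NC(=O)COc3ccc4c(=O)cc(-c5ccccc5)oc4c3)CC2)cc1`, gives 9300 nM in this assay, and the gap between compound 2 and compound 3 lies within the usual scatter of repeated measurements, so the two cannot be told apart on these numbers. Compound 2 is therefore one of two measured points, with no measured neighbour that differs from it in a single place.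

Compound 4, `O=C(COc1ccc(-c2cc(=O)c3ccccc3o2)cc1)NC1CCN(C(=O)c2ccccc2)CC1`, has not yet been measured. It differs from compound 2 in one place: benzoyl in place of 4-methoxybenzyl on an amine nitrogen in a ring. The amine nitrogen in the ring thus carries a benzoyl group instead of a 4-methoxybenzyl group, with one double bond outside aromatic rings entering and the group shrinking from 9 to 8 heavy atoms.

Going by the values given here, no measured pair shows a change of this kind, so any expectation rests on the uniformly weak cytotoxicity seen so far. A modest step toward a higher number, quite possibly not beyond the scatter, is expected. Compound 4 is expected to give about 11000 nM, with a plausible range from 3500 nM to 30000 nM. The expected change is then a 1.6-fold higher number from compound 2 to compound 4 (0.21 log units; within the scatter).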

Compound 4, half-maximal inhibitory concentration: > 20000 nM
Compound 4 was reported as a limit; the forecaster's own chance of this, stated with the estimate: 30%; middle value at least 1.8-fold (0.25 log units) from the limit.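

Going by these compounds alone, this is the first pair that differs in one place only, and it shows that the group on the amine nitrogen of the six-membered ring matters for the read-out in this assay: benzoyl in place of 4-methoxybenzyl gives an at least 2.9-fold higher number from compound 2 to compound 4 (0.46 log units; beyond the scatter). The two groups are close in heavy-atom count and each carries a six-membered aromatic ring of carbon only, and the counted difference that stands out is the double bond outside aromatic rings that benzoyl brings. Compound 4 gives > 20000 nM, which is a limit of the assay, so this step has no exact size, and the top of the scale now holds more of the series: the limit of > 20000 nM in this assay, at which 2 of the 4 values shown sit.

One pair cannot separate the effect of the carbonyl on the nitrogen from the effect of the methoxy group, since both change together, and a plain benzyl group on the same nitrogen would tell these two apart. The compounds shown also leave open how a small group such as methyl, or a free amine with no group on that nitrogen, would read in this assay.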